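A few compounds are considered here, and "the series" means these few. Any claim that something is new, unique, unknown or untested is made for them only; others in the source may bear on it.

Compound 1 `C[C@@H](NC(=S)Nc1cc(C(F)(F)F)cc(C(F)(F)F)c1)c1nc2ccccc2[nH]1` and compound 2 `CC(C)[C@@H](NC(=S)Nc1cc(C(F)(F)F)cc(C(F)(F)F)c1)c1nc2ccccc2[nH]1` share one core and differ in the alkyl group on the chain carbon. In a functional assay on DU-145 cells (Homo sapiens) for cytotoxicity, read by MTT assay (a higher number here means a weaker inhibitor, a lower number a stronger inhibitor), compound 1 gives 17600 nM and compound 2 gives 20200 nM; a 1.1-fold higher number from compound 1 to compound 2 (0.06 log units; within the scatter). Compound 2 therefore stands at the highest of the two numbers, with compound 1 nearest and within the scatter. Compound 3 `CC(C)[C@H](NC(=S)Nc1cc(C(F)(F)F)cc(C(F)(F)F)c1)c1nc2ccccc2[nH]1` differs from compound 2 as follows: the two compounds have the same atoms and bonds and differ only in configuration as drawn: 1 of 1 stereo elements differ; a stereocentre at a saturated chain carbon is drawn R in compound 2 and S in compound 3. Among the measured compounds shown here, no measured step concerns an inversion at this stereocentre; the only measured step, an alkyl swap, stayed within the scatter. No step beyond the scatter is expected in this assay. Compound 3 is estimated at 20000 nM, range 8000 nM to 50000 nM. The expected step is a 1.0-fold lower number from compound 2 to compound 3 (0.00 log units; within the scatter).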

Compound 3, half-maximal inhibitory concentration: 26100 nM
Compound 3: middle estimate off by 1.3-fold (0.12 log units), on the low side; measured number inside the range.
By their numbers in this assay, from the lowest: compounds 1, 2 and 3 (each within the scatter of the next).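

In this assay, among the compounds shown here, inverting the saturated chain carbon from R to S gives a 1.3-fold higher number from compound 2 to compound 3 (0.11 log units; within the scatter), the first reading of configuration at this position. This pair isolates configuration, with no group entering or leaving: the fact that compounds 2 and 3 differ only in the configuration as drawn. With the alkyl swap, a 1.1-fold higher number from compound 1 to compound 2 (0.06 log units; within the scatter), neither change at this carbon moves the number beyond the scatter in the compounds shown.

As far as these compounds go, whether configuration reads the same with the methyl group of compound 1 remains open. Also open, from the compounds shown here alone, is whether a carboxylic acid, an amine or a longer chain on this carbon would leave the number within the scatter.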